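Swapping Iodo for Nitro: Expected Toxicity of Compound 4

A few compounds are considered here, and "the series" means these few. Any claim that something is new, unique, unknown or untested is made for them only; others in the source may bear on it.

Of the compounds shown here, three sharing one core have been tested in a functional assay on HepG2 cells (Homo sapiens) for cytotoxicity, read by MTT assay; on this read-out higher numbers stand for lower toxicity in this test and lower numbers for higher toxicity in this test. Compound 1 `O=c1[nH]c(=O)n(COCCO)cc1[N+](=O)[O-]` carries a nitro group on the core; in this assay compound 1 gives only a limit of the assay, > 432000 nM. Compound 2 `Cc1cc(=O)[nH]c(=O)n1COCCO` carries a methyl group instead; in this assay compound 2 likewise gives only a limit, > 500000 nM. Compound 3 `Cc1c(I)c(=O)[nH]c(=O)n1COCCO` adds an iodo group to compound 2; in this assay compound 3 again gives only a limit, > 306000 nM. Among the measured compounds shown here, the one single-point step measured, a step that the two limits leave unreadable from compound 2 to compound 3, is therefore unreadable, since both of its ends are limits (the limit of > 500000 nM in this assay, at which 1 of the 3 values shown sits, and (the limit of > 306000 nM in this assay, at which 1 of the 3 values shown sits)). Compound 3 thus stands where every measured compound stands: no number, only a limit, with nothing separating it from compound 1 or compound 2.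

Compound 4 `Cc1c([N+](=O)[O-])c(=O)[nH]c(=O)n1COCCO` differs from compound 3 in one place: nitro in place of iodo on an aromatic carbon. For the measured compounds named here, no measured step speaks directly to this exchange. What does bear on it is that compound 1, which also carries a nitro group on the same core, stays at a limit (the limit of > 432000 nM in this assay, at which 1 of the 3 values shown sits). With all values shown being limits, no step beyond the scatter in either direction is expected in this assay, and compound 4 is expected to stay at or past the range measured, a step that the limit leaves unreadable from compound 3 to compound 4. The estimate for compound 4 in this assay is 450000 nM, within 150000 nM and 2000000 nM.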

Compound 4, half-maximal cytotoxic concentration: > 408000 nM
Compound 4: only a limit was reported; the forecaster's own chance of this, stated with the estimate: 85%; the middle value lies beyond the limit too.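

In this assay compound 4 gives > 408000 nM, which is a limit of the assay and not a number. The steps from compound 1, compound 2 and compound 3 to compound 4 cannot be read: all four values are limits. The compounds shown leave open at what concentration any of them would become toxic to these cells, and whether the nitro, iodo or methyl groups change that concentration at all.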